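This account rests on a few compounds, and the source may have more. Where it says the series, first, only, none or still open, it means among the compounds named here.

Measured so far:
compound 1, `OC(CCn1nc2c(Br)c(Br)c(Br)c(Br)c2n1)c1ccc(F)cc1`: 0%
compound 2, `C[C@@H](O)CCn1nc2c(Br)c(Br)c(Br)c(Br)c2n1`: 24%

In a functional assay on CCRF-CEM cells (Homo sapiens) for antiproliferative activity, read by MTT assay, with a stated time of 48 h, tested at 100 uM (a lower number here means a stronger effect, a higher number a weaker effect of the compound at the concentration tested), compound 1 gives 0%. In this assay, within the data shown here, compound 2 gives 24%, the higher of the two numbers; the gap between compound 1 and compound 2 lies beyond the scatter, but no single-point step is defined between them, so only the two values themselves stand on record.

Compound 3, `C[C@H](O)CCn1nc2c(Br)c(Br)c(Br)c(Br)c2n1`, is not yet measured in this assay. Compared with compound 2 it shows (the two compounds have the same atoms and bonds and differ only in configuration as drawn: 1 of 1 stereo elements differ; a stereocentre at a saturated chain carbon is drawn R in compound 2 and S in compound 3). Among the measured compounds shown here, no other pair differs only in configuration at a saturated chain carbon, so there is no precedent here for the size of such a step. For compound 3 the expected step of a number 4 percentage points lower from compound 2 to compound 3 (within the scatter) is set small, with no direction preferred, and the range is kept wide enough to admit a move beyond the scatter either way. Compound 3 is expected to give about 20% in this assay, between 0% and 45%.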

Compound 3, a percentage reported as activity, at one concentration (the size of the read-out at that concentration, not a potency): 10%
Estimate against measurement, compound 3: 10 percentage points above, within the range that was stated.
By their numbers in this assay, from the lowest: compounds 1 and 3 (each within the scatter of the next); then compound 2.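

In this assay the series now holds its first step that can be read at a single place: a number 14 percentage points lower from compound 2 to compound 3 (beyond the scatter). The change is from the R to the S drawing of the stereocentre at a saturated chain carbon, and a lower number here means a stronger effect at the concentration tested, so the S drawing has the stronger effect in this pair. Configuration at this carbon is enough to move the read-out beyond the scatter, and the step can be assigned to the stereocentre alone because no other feature separates the pair: the fact that compounds 2 and 3 differ only in the configuration as drawn

The compounds shown leave open what an amine or a ketone carbonyl would do to the read-out in place of the hydroxyl at this carbon, and whether the preference for the S drawing would persist with a longer chain on the shared core. This pair also gives a single reading at one concentration, so it cannot say how far the step reflects a difference in potency, nor why the configuration matters in these cells.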